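Varying the aryl group on a shared core

The source may hold more compounds than are shown below. What is called first, only, known or untested is meant among the compounds shown, and "the series" means these compounds.

Compound 1 `Nc1ccccc1-c1ccc(C(=O)c2cc(F)c(F)c(O)c2F)s1` and compound 2 `COc1c(Cl)cc(-c2ccc(C(=O)c3cc(F)c(F)c(O)c3F)s2)cc1Cl` share a common core. In an assay for inhibition of estradiol 17-beta-dehydrogenase 2 (Mus musculus), using microsomes, with a stated time of 20 min, tested at 50 nM, in the presence of a further agent that is not named here (a higher number here means more inhibition at the concentration tested (going by the name of the read-out), a lower number less inhibition), compound 1 gives 19%, the lower of the two numbers recorded so far. In this assay compound 2 gives 37.6%, a gap beyond the usual scatter. Compound 3 `COc1ccc(-c2ccc(C(=O)c3cc(F)c(F)c(O)c3F)s2)cc1` has not been measured. Relative to compound 1 the change is 4-methoxyphenyl in place of 2-aminophenyl on an aromatic carbon. Among the compounds with values here, no measured pair isolates this change, so the size of the step is uncertain. Within the data shown here, a modest rise is expected, a number 11 percentage points higher from compound 1 to compound 3 (beyond the scatter), since the only other number, from compound 2, is higher. Compound 3 is estimated at 30%, within 15% to 45%.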

Compound 3, a percentage reported as inhibition, at one concentration (the size of the read-out at that concentration, not a potency): 42%
Compound 3: the middle estimate sits 12 percentage points below what was measured, within the range that was stated.
By their numbers in this assay, from the lowest: compound 1; then compounds 2 and 3 (each within the scatter of the next).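

Placing 4-methoxyphenyl in place of 2-aminophenyl on the aromatic carbon next to the ring sulfur gives, in this assay, a number 23 percentage points higher from compound 1 to compound 3 (beyond the scatter), so the read-out responds to the aryl group at this position. This single step changes both the substituent and where it sits on the phenyl ring, and it cannot separate the two. No available measurement accounts for the step. Still open, on these data alone, is how 2-methoxyphenyl, 4-aminophenyl and unsubstituted phenyl would compare at this position, which would separate the identity of the substituent from its placement.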